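Aryl Swap on a Ring Nitrogen: Inhibition Expected Unchanged

This account rests on a few compounds, and the source may have more. Where it says the series, first, only, none or still open, it means among the compounds named here.

Among the compounds with values here, compound 1 `Nc1scc(CN2CCN(c3ccc(Cl)cc3F)CC2)c1C(=O)c1ccc(Cl)cc1` gives 0% in an assay on CHO cells for displacement of a labelled ligand from adenosine receptor A1 (Homo sapiens), read by scintillation counting, with a stated time of 120 min, tested at 10 uM (on this read-out lower numbers stand for less inhibition and higher numbers for more inhibition at the one concentration tested (going by the name of the read-out)), and the only other measured compound stands within the scatter of it: compound 2 `Nc1scc(CN2CCN(c3cccc4ccccc34)CC2)c1C(=O)c1ccc(Cl)cc1` gives 1%, the step being a number 1 percentage points higher from compound 1 to compound 2 (within the scatter). Compound 3 `Nc1scc(CN2CCN(c3ccccc3Cl)CC2)c1C(=O)c1ccc(Cl)cc1` differs from compound 1 by 2-chlorophenyl in place of 4-chloro-2-fluorophenyl on an amine nitrogen in a ring. Within the data shown here, the one measured step that also exchanges the group on the amine nitrogen in a ring, a number 1 percentage points higher from compound 1 to compound 2 (within the scatter), stayed within the scatter, so no step beyond the scatter is expected in this assay for compound 3. The expected step is a number 1 percentage points higher from compound 1 to compound 3 (within the scatter). Compound 3 is therefore estimated at 1%, with a range from -8% to 10%.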

Compound 3, a percentage reported as inhibition, at one concentration (the size of the read-out at that concentration, not a potency): 2%
The estimate for compound 3 lay 1 percentage points below the measured number; the range from low to high includes it.
By their numbers in this assay, from the lowest: compounds 1, 2 and 3 (each within the scatter of the next).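

In this assay, 2-chlorophenyl on the amine nitrogen in a ring gives a number 2 percentage points higher from compound 1 to compound 3 (within the scatter), and in place of naphthalen-1-yl it gives a number 1 percentage points higher from compound 2 to compound 3 (within the scatter). Neither the loss of the fluorine nor the exchange of the naphthalen-1-yl for a single six-membered aromatic ring separates these compounds at this position, so all three aryl groups read alike here. No supporting information on the cause bears on this result. From the compounds shown here alone, whether a benzyl group or an acetyl group on this nitrogen, or a carboxylic acid on the phenyl ring, would give a step beyond the scatter remains open.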